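The compounds below may be only part of what the source reports. "The series", "measured", "known", "first", "only" and "open" are said of these compounds alone.

Measured compounds, with their results in a functional assay on cells for positive allosteric modulation of metabotropic glutamate receptor 2 (Homo sapiens), read by fluorescence and calcium flux, with a stated time of 30 min; a lower number here means that less compound is needed, a higher number that more compound is needed for the effect:

Compound 1 `Fc1ccc(-c2ccc(Cn3nnc4ccccc43)cc2)c(F)c1` gives 71 nM.
Compound 2 `Brc1cccc2c1nnn2Cc1ccccc1` gives 80 nM.
Compound 3 `Brc1cccc2c1nnn2CC1CC1` gives 70 nM.

The three values sit close together. Compound 3 returns the lowest number of the three, but its gap to compound 1 and its gap to compound 2 both lie within the scatter of repeated measurements, so no ordering among them can be claimed, and none of the three can be called the most potent. Compound 2 and compound 3 share the same core and differ only in what hangs on the saturated chain carbon bound to an aromatic nitrogen; their two values show no separation beyond the scatter.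

Compound 4 `CCn1nnc2c(Br)cccc21` is the next member of this set and has not yet been measured. It differs from compound 3 in one place: methyl in place of cyclopropyl on a saturated chain carbon bound to an aromatic nitrogen. For the measured compounds named here, no measured pair in this set isolates the same change, so no directly comparable step exists. Given that the swap between benzyl and cyclopropylmethyl on the same carbon, compound 2 against compound 3, shows no separation beyond the scatter, a small change at this position is expected to leave the number roughly where it is, with at most a modest move toward a higher value. Compound 4 is therefore expected to give 110 nM, with a range from 45 nM to 280 nM, meaning an estimated step of a 1.6-fold higher number from compound 3 to compound 4 (0.20 log units; within the scatter) in this assay.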

Compound 4, half-maximal effective concentration: 2240 nM
The estimate for compound 4 lay 20-fold (1.31 log units) below the measured number, and the stated range ends below it.
By their numbers in this assay, from the lowest: compounds 3, 1 and 2 (each within the scatter of the next); then compound 4.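

In this assay, a 32-fold higher number from compound 3 to compound 4 (1.51 log units; beyond the scatter) shows that the saturated chain carbon bound to an aromatic nitrogen is far from indifferent to what it carries, and that methyl in place of cyclopropyl there costs a large step. The earlier pair could not show this, as compound 2 at 80 nM and compound 3 at 70 nM lie within the scatter of each other, so benzyl and cyclopropylmethyl gave no sign that this place matters; the new result shows that this agreement does not extend to ethyl, the same difference cut one bond further out. Nothing at hand explains the step, as no supporting measurement bears on it.

The compounds shown leave open whether a ring on this carbon is itself required or whether a longer chain such as propyl or butyl would restore values like those of compound 2 and compound 3. They also leave open how an amine or a carboxylic acid would read at this place, and whether methyl in place of cyclopropyl would give a step of similar size on another core.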